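Oxime Double-Bond Geometry Swap in a Piperazine Series

This account rests on a few compounds, and the source may have more. Where it says the series, first, only, none or still open, it means among the compounds named here.

Compound 1 `O/N=C(/CCN1CCN(c2ccccn2)CC1)c1ccccc1`: 21.7 nM
Compound 2 `N#Cc1cccnc1N1CCN(CC/C(=N\O)c2ccccc2)CC1`: 18 nM

In a functional assay on HEK293 cells with D(4) dopamine receptor (Homo sapiens) as the target, read by FLIPR (on this read-out lower numbers stand for an effect already at smaller amounts and higher numbers for an effect only at larger amounts of compound), compound 1 gives 21.7 nM and compound 2 gives 18 nM. Compound 2 has the lowest of the two numbers, yet compound 1 lies within the scatter of it, so no order can be read between them. Among the compounds with values here, compound 3 `N#Cc1cccnc1N1CCN(CC/C(=N/O)c2ccccc2)CC1` is not yet measured. the two compounds have the same atoms and bonds and differ only in configuration as drawn: 1 of 1 stereo elements differ; a double bond is drawn E in compound 2 and Z in compound 3 No measured pair covers a change of double-bond geometry, so the size and direction of this step rest on no data. Compound 3 is estimated at 60 nM, in a range from 10 nM to 400 nM. The expected step of a 3.3-fold higher number from compound 2 to compound 3 (0.52 log units; beyond the scatter) points toward a somewhat higher number in this assay, with wide uncertainty.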

Compound 3, half-maximal effective concentration: 20 nM
For compound 3 the middle estimate is 3.0-fold (0.48 log units) above the measured one, and the stated range covers the measured number.
By their numbers in this assay, from the lowest: compounds 2, 3 and 1 (each within the scatter of the next).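

In this assay, changing the oxime double bond from E to Z gives a 1.1-fold higher number from compound 2 to compound 3 (0.05 log units; within the scatter), so this position shows no readable dependence on geometry in this pair. This comparison isolates geometry alone: the fact that compounds 2 and 3 differ only in the configuration as drawn The cyano change can now also be read by itself, as cyano in place of hydrogen on an aromatic carbon gives a 1.1-fold lower number from compound 1 to compound 3 (0.04 log units; within the scatter), again no readable difference.

Still open, as far as these compounds go, is whether geometry stays this silent when a methyl ether replaces the oxime hydroxyl or a longer chain links the oxime carbon to the piperazine.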